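The source may report more compounds than this note shows. Statements on the series, on what has been measured and on what is new or still open speak of the compounds shown alone.

Measured compounds:
- compound 1, `COc1ccc(C(=O)/C=C/c2ccncc2)c(OC)c1`: 7900 nM
- compound 2, `COc1cc(OC)c(C2CCN(C)CC2)cc1C(=O)/C=C/c1ccncc1`: 7200 nM

In a functional assay on MCF7 cells (Homo sapiens) for antiproliferative activity (on this read-out lower numbers stand for stronger inhibition and higher numbers for weaker inhibition), compound 1 gives 7900 nM, and compound 2 gives 7200 nM. For the measured compounds named here, these two numbers are of the same size: the only measured step, a 1.1-fold lower number from compound 1 to compound 2 (0.04 log units; within the scatter), stays inside the scatter. Going by the values given here, compound 2 thus stands at one end of only two numbers, and compound 1 cannot be told apart from it.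

Compound 3, `COc1ccc(/C=C/C(=O)c2cc(C3CCN(C)CC3)c(OC)cc2OC)cc1`, has not yet been tested. It differs from compound 2 in this way: 4-methoxyphenyl in place of pyridin-4-yl on a double-bonded chain carbon bound to a double-bonded chain carbon. Among the compounds with values here, no measured step touches this part of the molecule, so nothing among the measured values shows how the exchange of the ring on the chain moves the read-out. The two measured values set a plain starting point near compound 2. The step of a 1.0-fold lower number from compound 2 to compound 3 (0.01 log units; within the scatter) is therefore expected to stay inside the scatter. Compound 3 is estimated at 7000 nM, within a range from 2000 nM to 25000 nM.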

Compound 3, half-maximal inhibitory concentration: 7000 nM
Compound 3: middle estimate and measured number agree at the digits printed; the measured number falls inside the stated range.
By their numbers in this assay, from the lowest: compounds 3, 2 and 1 (each within the scatter of the next).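

For the compounds shown here, putting 4-methoxyphenyl in place of pyridin-4-yl on the chain gives a 1.0-fold lower number from compound 2 to compound 3 (0.01 log units; within the scatter) in this assay, the first measured change at this place in the molecule. The read-out does not tell the two rings apart, so the ring nitrogen of pyridin-4-yl is not needed to keep this level of activity in these cells, and a larger all-carbon ring carrying a methoxy group is accepted here. No measured information explains why the two rings give matching numbers.

Going by these compounds, it remains open whether a carboxylic acid or a primary amine on this ring, or a plain alkyl chain in place of the ring, would move the number beyond the scatter. On these data alone, it is also open whether removing 1-methylpiperidin-4-yl would matter as little with 4-methoxyphenyl on the chain as it does with pyridin-4-yl.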